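Series notes: imidazole to benzimidazole acid on the ring amine

The source may hold more compounds than are shown below. What is called first, only, known or untested is meant among the compounds shown, and "the series" means these compounds.

Compound 2 `OC[C@@H](O[C@H]1CCCN(Cc2ncc[nH]2)[C@H]1c1ccccc1)c1cc(Cl)cc(Cl)c1` is the reference here. In an assay on isolated protein for activation of cGMP-dependent protein kinase 1 (Homo sapiens), read by ADP-Glo, with stated times of 30 min and 2 h (on this read-out lower numbers stand for an effect already at smaller amounts and higher numbers for an effect only at larger amounts of compound), compound 2 gives only a limit, > 200000 nM, and no number. Compound 1 `O=C(O)C12CC(CN3CCC[C@H](O[C@H](CO)c4cc(Cl)cc(Cl)c4)[C@@H]3c3ccccc3)(C1)C2` carries a different group on the same saturated chain carbon bound to the amine nitrogen in the ring, and in this assay compound 1 likewise reaches only the limit > 200000 nM. Compound 3 `Cc1cc(C(=O)O)ccc1C(C)N1CCC[C@H](O[C@H](CO)c2cc(Cl)cc(Cl)c2)[C@@H]1c1ccccc1` belongs to the same set but in this assay compound 3 has "nd" (no result reported). Going by the values given here, the one step that connects measured compounds, a step that the two limits leave unreadable from compound 1 to compound 2, cannot be read, because the limit of > 200000 nM in this assay, at which 2 of the 3 values shown sit, sits at both ends of it. Compound 2 therefore stands at the limit with one neighbour also at the limit and the other without a value.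

The compound to be measured is compound 4 `O=C(O)c1ccc2nc(CN3CCC[C@H](O[C@H](CO)c4cc(Cl)cc(Cl)c4)[C@@H]3c3ccccc3)[nH]c2c1`. Against compound 2 the change is a group of 12 heavy atoms (8 carbon, 2 nitrogen, 2 oxygen; one five-membered aromatic ring with 2 hetero atoms, one six-membered aromatic ring of carbon only) in place of a group of 5 heavy atoms (3 carbon, 2 nitrogen; one five-membered aromatic ring with 2 hetero atoms), on a saturated chain carbon bound to an amine nitrogen in a ring. Among the compounds with values here, no measured step bears on this change in a readable way, since the step from compound 1 to compound 2 is blocked by the limit on both sides. The expectation for compound 4 rests only on compound 2 sitting at > 200000 nM, so compound 4 is expected near the same limit, with the step that the limit leaves unreadable from compound 2 to compound 4 estimated as essentially none beyond the scatter. Compound 4 is thus estimated at 250000 nM, in the range 40000 nM to 1500000 nM.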

Compound 4, half-maximal effective concentration: 43000 nM
Compound 4: the middle estimate sits 5.8-fold (0.76 log units) above what was measured; the measured number falls inside the stated range.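

In this assay, compound 4 is the only compound shown that gives a number rather than a limit, so the saturated chain carbon bound to the amine nitrogen in the ring is a place where the group changes the read-out. Replacing 1H-imidazol-2-yl with the group that adds a six-membered aromatic ring of carbon only and a carboxylic acid gives an at least 4.6-fold lower number from compound 2 to compound 4 (0.66 log units; beyond the scatter), and replacing the group with 2 four-membered non-aromatic rings gives an at least 4.6-fold lower number from compound 1 to compound 4 (0.66 log units; beyond the scatter); since compound 1 also carries a carboxylic acid and compound 2 also carries the five-membered aromatic ring with 2 hetero atoms, neither feature alone gives a number among these compounds. The true size of both steps stays unknown, because each starts from a limit: the limit of > 200000 nM in this assay, at which 2 of the 4 values shown sit.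

The compounds shown do not separate the contribution of the carboxylic acid from that of the six-membered aromatic ring, as neither the same two aromatic rings without the acid nor the 1H-imidazol-2-yl group bearing a carboxylic acid is among them. From the compounds shown here alone, whether a primary amide or a methyl ester could stand in place of the carboxylic acid also remains open.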